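Benzoyl for Acetyl Across Two Related Cores

The source may hold more compounds than are shown below. What is called first, only, known or untested is meant among the compounds shown, and "the series" means these compounds.

Measured compounds:
Compound 1, `CC(=O)Nc1cc(NC(=O)Nc2cccc(Oc3ccccc3)c2)ccc1C`, gives > 30000 nM.
Compound 2, `Cc1ccc(NC(=O)Nc2cccc(Oc3ccccc3)c2)cc1NC(=O)c1ccccc1`, gives > 30000 nM.
Compound 3, `CC(=O)Nc1cc(NC(=O)c2ccc(Cl)c(C(F)(F)F)c2)ccc1C`, gives > 30000 nM.

All three compounds were tested in a functional assay on A375P cells (Homo sapiens) for antiproliferative activity; on this read-out higher numbers stand for weaker inhibition and lower numbers for stronger inhibition. For compound 1 the value > 30000 nM is a limit of the assay, not a number. For compound 2 the value > 30000 nM is likewise a limit. For compound 3 the value > 30000 nM is a limit as well. Taken together, this is the limit of > 30000 nM in this assay, at which 3 of the 3 values shown sit.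

Compound 1 and compound 2 differ in one place, (phenyl in place of methyl on a carbonyl carbon). In this assay the step is a step that the two limits leave unreadable from compound 1 to compound 2, so the effect of this change on the first core cannot be read from the data.

Compound 4, `Cc1ccc(NC(=O)c2ccc(Cl)c(C(F)(F)F)c2)cc1NC(=O)c1ccccc1`, has not yet been measured. It relates to compound 3 as compound 2 relates to compound 1: the change is phenyl in place of methyl on a carbonyl carbon, in the same place and with the same surroundings, so it is the same change made on a second core. The difference between the two cores, that of compound 1 and that of compound 3, is not broken down here.

Among the measured compounds shown here, since compound 3 sits at the limit and the only measured example of this change ends at a limit too, the step from compound 3 to compound 4 is expected to be a step that the limit leaves unreadable from compound 3 to compound 4. Compound 4 is thus estimated at 40000 nM, most likely again reported only as a limit, with a plausible range from 15000 nM to 100000 nM.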

Compound 4, half-maximal inhibitory concentration: > 30000 nM
Compound 4 gave a limit, no number; the forecaster's own chance of this, stated with the estimate: 85%; the middle value is on the limit's open side.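

In this assay compound 4 gives > 30000 nM, a limit of the assay and not a number. Compound 3 also stands at a limit, and the step between compound 3 and compound 4 cannot be read. All the results stop at the same point: the limit of > 30000 nM in this assay, at which 4 of the 4 values shown sit.

The compounds shown leave open whether benzoyl in place of acetyl changes activity on either core.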